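From Fluoro to Phenyl on Compound 2

The compounds below may be only part of what the source reports. "The series", "measured", "known", "first", "only" and "open" are said of these compounds alone.

Three measured compounds share one core and differ only in the group on the saturated chain carbon bound to an amide-type nitrogen in a ring. Compound 1 `Cc1ccc(CN2CCc3ncn(COCc4ccccc4)c3/C(=C/c3ccccc3)C2=O)cc1` carries a 4-methylphenyl there, and in a functional assay on HCT-116 cells (Homo sapiens) for inhibition, read by MTT assay, with a stated time of 72 h (a lower number here means a stronger inhibitor, a higher number a weaker inhibitor), compound 1 gives 7940 nM. Compound 2 `O=C1/C(=C\c2ccccc2)c2c(ncn2COCc2ccccc2)CCN1Cc1ccc(F)cc1` carries a 4-fluorophenyl and gives 11200 nM. Compound 3 `Cc1cc(C)cc(CN2CCc3ncn(COCc4ccccc4)c3/C(=C/c3ccccc3)C2=O)c1` carries a 3,5-dimethylphenyl and gives 6230 nM. Compound 2 has the highest number of the three, yet every gap is within the scatter: a 1.4-fold higher number from compound 1 to compound 2 (0.15 log units; within the scatter), a 1.3-fold lower number from compound 1 to compound 3 (0.11 log units; within the scatter), and a 1.8-fold lower number from compound 2 to compound 3 (0.25 log units; within the scatter).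

Compound 4 `O=C1/C(=C\c2ccccc2)c2c(ncn2COCc2ccccc2)CCN1Cc1ccc(-c2ccccc2)cc1` has not yet been measured. It differs from compound 2 by phenyl in place of fluoro on an aromatic carbon. The step that bears most directly on it is the one at the same aromatic carbon, a 1.4-fold higher number from compound 1 to compound 2 (0.15 log units; within the scatter), which stayed within the scatter; the other two steps, a 1.3-fold lower number from compound 1 to compound 3 (0.11 log units; within the scatter) and a 1.8-fold lower number from compound 2 to compound 3 (0.25 log units; within the scatter), also stayed within the scatter. For the measured compounds named here, no measured step introduces a phenyl at this position, so the direction is open. The expectation is therefore a step of a 1.4-fold lower number from compound 2 to compound 4 (0.15 log units; within the scatter), with no strong lean either way. Compound 4 is estimated at 8000 nM, within a range from 3000 nM to 25000 nM.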

Compound 4, half-maximal inhibitory concentration: 14000 nM
Compound 4: the middle estimate sits 1.8-fold (0.24 log units) below what was measured; low and high end bracket the measured number.
By their numbers in this assay, from the lowest: compounds 3, 1, 2 and 4 (each within the scatter of the next, the first and the last beyond it).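

In this assay, replacing the fluoro with a whole phenyl ring on this aromatic carbon gives a 1.3-fold higher number from compound 2 to compound 4 (0.10 log units; within the scatter), so even a much larger group here leaves the number within the scatter of the fluoro compound. Replacing the methyl with the same phenyl tells the same story, with a 1.8-fold higher number from compound 1 to compound 4 (0.25 log units; within the scatter), and together these two steps show that, across fluoro, methyl and phenyl, this position has not yet produced a step beyond the scatter. For the compounds shown here, the only such step in the set comes from comparing two differently substituted benzyl-type groups, a 2.2-fold higher number from compound 3 to compound 4 (0.35 log units; beyond the scatter), and it is modest, so the 3,5-dimethylphenyl and 4-phenylphenyl groups are the only pair here that can be told apart.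

No measurement shown here explains why these groups give the numbers they do. Going by these compounds, whether a group of a different kind on this aromatic carbon, such as an amine or a carboxylic acid, would move the number well beyond the scatter remains open, and so does whether any change at this position can bring it far below the values seen so far.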